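A few compounds are considered here, and "the series" means these few. Any claim that something is new, unique, unknown or untested is made for them only; others in the source may bear on it.

Measured so far:
compound 1 `CCn1c(C(=O)NCCN(C)C)ccc1C(CC)(CC)c1ccc(OCCC(O)(CC)CC)c(C)c1` — 82 nM
compound 2 `CCn1c(C(=O)N(CCC#N)CCC#N)ccc1C(CC)(CC)c1ccc(OCCC(O)(CC)CC)c(C)c1` — only a limit reported
compound 3 `CCn1c(C(=O)Nc2cccc(C(F)(F)F)c2)ccc1C(CC)(CC)c1ccc(OCCC(O)(CC)CC)c(C)c1` — 5900 nM

In an assay on cells for agonist activity at vitamin D3 receptor (Homo sapiens), with a stated time of 96 h (on this read-out lower numbers stand for an effect already at smaller amounts and higher numbers for an effect only at larger amounts of compound), compound 1 gives 82 nM. Compound 2 gives no number in this assay but only a limit, > 10000 nM. Compound 3 gives 5900 nM. Compound 2 thus stands at the floor of the series, (the limit of > 10000 nM in this assay, at which 1 of the 3 values shown sits); the step of an at least 120-fold higher number from compound 1 to compound 2 (2.08 log units; beyond the scatter) is the largest seen, and the step of a 72-fold higher number from compound 1 to compound 3 (1.86 log units; beyond the scatter) is of comparable size. Between the two weaker amides, an at least 1.6-fold lower number from compound 2 to compound 3 (0.22 log units; that floor lies within the scatter), so the gap is not resolved.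

Compound 4 `CCOc1ccc(NC(=O)c2ccc(C(CC)(CC)c3ccc(OCCC(O)(CC)CC)c(C)c3)n2CC)cc1` carries an aryl amide in place of the group bearing two nitriles: a group of 10 heavy atoms (8 carbon, 1 nitrogen, 1 oxygen; one six-membered aromatic ring of carbon only) in place of a group of 9 heavy atoms (6 carbon, 3 nitrogen; no ring), on a carbonyl carbon. The step bearing most directly on it is the one to the other aryl amide, compound 3, whose value 5900 nM sits just inside the measurable range. The expected step is therefore a modest lowering from the limit, an at least 2.5-fold lower number from compound 2 to compound 4 (0.39 log units; beyond the scatter), with a real chance that only a limit is returned again. Compound 4 is estimated at 4000 nM, in the range 1000 nM to 15000 nM.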

Compound 4, half-maximal effective concentration: 1630 nM
Compound 4: middle estimate off by 2.5-fold (0.39 log units), on the high side; low and high end bracket the measured number.
By their numbers in this assay, from the lowest: compound 1; then compound 4; then compound 3. At a limit, above all of these: compound 2.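

In this assay, going by these compounds alone, the aryl group on the amide-type nitrogen now proves able to shift the read-out, with a 3.6-fold lower number from compound 3 to compound 4 (0.56 log units; beyond the scatter), a difference that the earlier compounds left unresolved. Even so, 2-(dimethylamino)ethyl remains ahead of 4-ethoxyphenyl, with a 20-fold higher number from compound 1 to compound 4 (1.30 log units; beyond the scatter), so both aryl amides shown give higher numbers than compound 1. The step from the group bearing two nitriles is only a floor, an at least 6.1-fold lower number from compound 2 to compound 4 (0.78 log units; beyond the scatter), and its true size cannot be read, as one end of it is a limit: the limit of > 10000 nM in this assay, at which 1 of the 4 values shown sits.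

Going by these compounds, it remains open whether the difference between the two aryl amides follows from the ethoxy group, from its place on the ring, or from the absence of trifluoromethyl. Also open, on these data alone, is whether another amine on a two-carbon chain, or a carboxylic acid there, would match compound 1.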